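Working notes: anilide halogen swap and cell growth inhibition

The source may report more compounds than this note shows. Statements on the series, on what has been measured and on what is new or still open speak of the compounds shown alone.

Measured so far:
Compound 1, `CC1=C(C(=O)Nc2ccc(F)c(Cl)c2)C(c2cccc(Oc3ccccc3)c2)NC(=S)N1`, in a functional assay on HOP-92 cells (Homo sapiens) for cytotoxicity, read by sulforhodamine B assay, with a stated time of 48 h (on this read-out higher numbers stand for weaker inhibition of growth and lower numbers for stronger inhibition of growth), gives 20900 nM.
Compound 2, `CC1=C(C(=O)Nc2ccc(Cl)c(Cl)c2)C(c2cccc(Oc3ccccc3)c2)NC(=S)N1`, in this assay gives 13200 nM.
Compound 3, `COc1cccc(C2NC(=S)NC(C)=C2C(=O)Nc2ccc(Cl)c(Cl)c2)c1`, in this assay gives 12600 nM.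

Compound 2 and compound 3 differ only at the ether: methyl in place of phenyl on an oxygen on an aromatic ring. That change produced a 1.0-fold lower number from compound 2 to compound 3 (0.02 log units; within the scatter). From compound 2 to compound 1 the change is fluoro in place of chloro on an aromatic carbon, and it produced a 1.6-fold higher number from compound 2 to compound 1 (0.20 log units; within the scatter).

Compound 4, `COc1cccc(C2NC(=S)NC(C)=C2C(=O)Nc2ccc(F)c(Cl)c2)c1`, is not yet measured. Against compound 3 it carries fluoro in place of chloro on an aromatic carbon, the same change at the same place as the one already measured on the other core.

For compound 4 in this assay the expected step from compound 3 is a 1.4-fold higher number from compound 3 to compound 4 (0.15 log units; within the scatter). This expectation rests on the measured step of a 1.6-fold higher number from compound 2 to compound 1 (0.20 log units; within the scatter), which stayed within the scatter. Compound 4 is accordingly estimated at 18000 nM, with a likely range of 9000 nM to 36000 nM.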

Compound 4, concentration for 50% growth inhibition: 50100 nM
Estimate against measurement, compound 4: 2.8-fold (0.44 log units) below; measured number outside the range, above it.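

In this assay, fluoro in place of chloro on the core of compound 3 gives a 4.0-fold higher number from compound 3 to compound 4 (0.60 log units; beyond the scatter) and this step does not separate from its counterpart on the core of compound 2: the same change on two cores in this assay, a 1.6-fold higher number (0.20 log units; within the scatter) from compound 2 to compound 1 and a 4.0-fold higher number (0.60 log units; beyond the scatter) from compound 3 to compound 4, 2.5-fold (0.40 log units) apart, within the scatter of two such steps.
Methyl in place of phenyl on the oxygen gives a 2.4-fold higher number from compound 1 to compound 4 (0.38 log units; beyond the scatter) and the comparison across the two anilides reads the same way: the same change on two cores in this assay, a 1.0-fold lower number (0.02 log units; within the scatter) from compound 2 to compound 3 and a 2.4-fold higher number (0.38 log units; beyond the scatter) from compound 1 to compound 4, 2.5-fold (0.40 log units) apart, within the scatter of two such steps.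
Neither change is shown to depend on the core, but with a single pair of steps for each change, and each pair holding one step within the scatter and one beyond it, transfer between cores is not established either.

From the compounds shown here alone, whether a bromo or trifluoromethyl group in place of the chloro would follow the same steps remains open. So does the behaviour of an ethyl or benzyl group on the oxygen.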